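Swapping a Side Group on a Shared Core: Cytotoxicity

A few compounds are considered here, and "the series" means these few. Any claim that something is new, unique, unknown or untested is made for them only; others in the source may bear on it.

Compound 1: `Cc1ccccc1CNc1nn(-c2ccc(F)cc2F)cc1CNCCN1CCN(C)CC1` — > 20000 nM
Compound 2: `Cc1ccccc1-c1nn(-c2ccc(F)cc2F)cc1CNCCCN1CCN(C)CC1` — > 20000 nM

In an ADME assay on Huh-7 cells (Homo sapiens) for cytotoxicity (a higher number here means that more compound is tolerated, a lower number that less compound is tolerated), compound 1 gives > 20000 nM, which is a limit of the assay rather than a number. Compound 2 gives > 20000 nM, likewise a limit of the assay. On the numbers shown, compound 1 therefore stands at the limit of > 20000 nM in this assay, at which 2 of the 2 values shown sit, the top of what this assay reports, with nothing to rank it against.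

Compound 3, `CN1CCN(CCNCc2cn(-c3ccc(F)cc3F)nc2-c2ccc(C(F)(F)F)cc2)CC1`, has not yet been measured. It differs from compound 1 in one place: 4-(trifluoromethyl)phenyl in place of (2-methylbenzyl)amino on an aromatic carbon. With compound 1 and compound 2 both sitting at the limit, no step beyond the scatter is expected in this assay for this change. Compound 3 is expected to give 25000 nM, with a range from 8000 nM to 60000 nM. The step that the limit leaves unreadable from compound 1 to compound 3 is thus estimated as none beyond the scatter, most likely again reported only as a limit.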

Compound 3, half-maximal cytotoxic concentration: 20000 nM
Compound 3: the middle estimate sits 1.3-fold (0.10 log units) above what was measured, and the stated range covers the measured number.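

In this assay compound 3 gives 20000 nM as an actual number, the only one among the compounds shown, so the place on the shared core that holds (2-methylbenzyl)amino in compound 1 can carry 4-(trifluoromethyl)phenyl with a measured cytotoxicity value. Compound 1 gives > 20000 nM as a limit of the assay and not a number. The change of group therefore gives a number no higher from compound 1 to compound 3 (the limit leaves the size open) and the size of this step cannot be read, and what stands in the way is this: the limit of > 20000 nM in this assay, at which 2 of the 3 values shown sit.

The compounds shown leave open whether a plain amine or a carboxylic acid at this place would give a number clearly lower than that of compound 3. They also leave open how a longer chain in place of the 4-(trifluoromethyl)phenyl would read.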